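Opening the Ring: Estimating Compound 4 in Cytotoxicity

A few compounds are considered here, and "the series" means these few. Any claim that something is new, unique, unknown or untested is made for them only; others in the source may bear on it.

Measured so far:
- Compound 1 `COc1ccc(/C=C\c2cc(OC)c(OC)c(OC)c2)cc1OCc1ccc(CN2CC(C(=O)O)C2)cc1`: in an ADME assay on HEK293 cells (Homo sapiens) for cytotoxicity, read by CCK-8 assay, with a stated time of 48 h (a lower number here means a stronger inhibitor, a higher number a weaker inhibitor), compound 1 reaches only a limit of the assay, > 50000 nM.
- Compound 2 `COc1ccc(/C=C\c2cc(OC)c(OC)c(OC)c2)cc1OCc1ccc(CN2CC[C@@H](O)C2)cc1`: in this assay compound 2 also reaches only a limit, > 50000 nM.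
- Compound 3 `COc1ccc(/C=C\c2cc(OC)c(OC)c(OC)c2)cc1OCc1ccc(CN2CC[C@@H](C(=O)O)C2)cc1`: in this assay compound 3 gives 27000 nM.

Compound 3 is thus the only one of the three with a true number; the other two sit at a limit, as summarised by the limit of > 50000 nM in this assay, at which 2 of the 3 values shown sit. Going by these compounds, the steps leading to it are an at least 1.8-fold lower number from compound 1 to compound 3 (0.26 log units; that floor lies within the scatter) and an at least 1.8-fold lower number from compound 2 to compound 3 (0.26 log units; that floor lies within the scatter), and both rest on a limit, so their true size is unknown; the step that the two limits leave unreadable from compound 1 to compound 2 cannot be read at all.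

Compound 4 `COc1ccc(/C=C\c2cc(OC)c(OC)c(OC)c2)cc1OCc1ccc(CN[C@H](C(=O)O)[C@@H](C)O)cc1` has not been measured. It differs from compound 3 by (1-carboxy-2-hydroxypropyl)amino in place of 3-carboxypyrrolidin-1-yl on a saturated chain carbon bound to an aromatic carbon. The carboxy is kept, a hydroxy is added, and the ring is lost. Since the carboxy-bearing compound 3 is the only one below the limit while the hydroxy-bearing compound 2 is not, the change gives no clear direction; a number near or at the limit is expected, with a modest expected step of a 1.5-fold higher number from compound 3 to compound 4 (0.17 log units; within the scatter). Compound 4 is therefore estimated at 40000 nM, within 15000 nM to 100000 nM.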

Compound 4, half-maximal inhibitory concentration: > 50000 nM
Compound 4 was reported as a limit; the forecaster's own chance of this, stated with the estimate: 45%; at least 1.2-fold (0.09 log units) between middle value and limit.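

Placing (1-carboxy-2-hydroxypropyl)amino where 3-carboxypyrrolidin-1-yl stood, on a saturated chain carbon bound to an aromatic carbon, gives an at least 1.8-fold higher number from compound 3 to compound 4 (0.26 log units; that floor lies within the scatter), and this is only a floor, so the true step could be larger. Compound 1 had already shown that a carboxy on a different ring, in 3-carboxyazetidin-1-yl, can leave a compound at the limit, and compound 4 now shows the same for a carboxy on an open chain that also bears a hydroxy. Compound 3 therefore remains the only compound with a true number, and the steps from compound 1 and from compound 2 to compound 4 run from limit to limit and cannot be read, which leaves this picture: the limit of > 50000 nM in this assay, at which 3 of the 4 values shown sit.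

Compound 4 changes two things at once, losing the ring and gaining a hydroxy, so the compounds shown cannot separate the two changes. An open chain with the carboxy but no hydroxy, or a piperidine ring carrying the carboxy, would show in this assay whether a true number depends on the five-membered ring of compound 3.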